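The source may report more compounds than this note shows. Statements on the series, on what has been measured and on what is new or still open speak of the compounds shown alone.

Of the compounds shown here, two have been measured in an assay for inhibition of 6-phosphofructo-2-kinase/fructose-2,6-bisphosphatase 3 (Homo sapiens), read by ADP-Glo, with a stated time of 2 h; a higher number here means a weaker inhibitor, a lower number a stronger inhibitor. Compound 1 `CN(C)S(=O)(=O)c1ccccc1Nc1cc(-c2ccc3ccn(C)c3c2)c2nccnc2c1` gives 94 nM. Compound 2 `Cn1cc(CNC(=O)c2ccncc2Nc2cc(-c3ccc4ccn(C)c4c3)c3nccnc3c2)cn1` gives 159 nM, the higher of the two numbers, though its gap to compound 1 lies within the usual scatter, so the two are not separated. Compound 3 `CN1CC(NC(=O)c2ccncc2Nc2cc(-c3ccc4ccn(C)c4c3)c3nccnc3c2)CCC1=O` has not yet been measured. It differs from compound 2 in one place: 1-methyl-6-oxopiperidin-3-yl in place of (1-methyl-1H-pyrazol-4-yl)methyl on an amide-type nitrogen. For the measured compounds named here, no step between two measured compounds bears on this change, and the two numbers in hand give no direction for it. The step in this assay from compound 2 to compound 3 is therefore expected to be small, a 1.3-fold higher number from compound 2 to compound 3 (0.10 log units; within the scatter), in neither direction beyond the scatter. Compound 3 is accordingly estimated at 200 nM, with a range from 70 nM to 600 nM.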

Compound 3, half-maximal inhibitory concentration: 116 nM
For compound 3 the middle estimate is 1.7-fold (0.24 log units) above the measured one, within the range that was stated.
By their numbers in this assay, from the lowest: compounds 1, 3 and 2 (each within the scatter of the next).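

On the amide-type nitrogen, 1-methyl-6-oxopiperidin-3-yl can take the place of (1-methyl-1H-pyrazol-4-yl)methyl without a separable effect in this assay: the change gives a 1.4-fold lower number from compound 2 to compound 3 (0.14 log units; within the scatter). This position therefore accepts a six-membered non-aromatic ring as well as a five-membered aromatic one, so in this pair the aromatic ring of the departing group is not required to keep the number within the scatter. No measurement at hand accounts for this result.

From the compounds shown here alone, it remains open whether an open chain on this nitrogen, such as a plain methyl or a longer alkyl chain, or a group carrying an amine or a carboxylic acid, would shift the number beyond the scatter. Compound 1 differs from compound 2 and compound 3 in more than one place, so it adds nothing on this question.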